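Arylpiperazine amides at the serotonin 7 receptor

This account rests on a few compounds, and the source may have more. Where it says the series, first, only, none or still open, it means among the compounds named here.

Measured in an assay on HEK293 cells for displacement of a labelled ligand from 5-hydroxytryptamine receptor 7 (Homo sapiens), with a stated time of 1 h; on this read-out higher numbers stand for weaker inhibition and lower numbers for stronger inhibition:
- compound 1, `NC(=O)[C@@H]1CCCN1C(=O)CCCCCN1CCN(c2cccc(Cl)c2)CC1`, gives 478 nM
- compound 2, `NC(=O)[C@@H]1CCCN1C(=O)CCCCN1CCN(c2noc3ccccc23)CC1`, gives 108 nM
- compound 3, `CSc1ccccc1N1CCN(CCCCC(=O)N2Cc3ccccc3C[C@H]2C(N)=O)CC1`, gives 51 nM

Compound 3 stands lowest of the three and is the most potent in this assay, its gaps to compound 2 and compound 1 both lying beyond the usual scatter. Compound 4, `NC(=O)[C@@H]1Cc2ccccc2CN1C(=O)CCCCN1CCN(c2ccc(Cl)cc2)CC1`, keeps the core of compound 3 and differs only in one change: 4-chlorophenyl in place of 2-(methylsulfanyl)phenyl on an amine nitrogen in a ring. Among the measured compounds shown here, no measured pair shows this exact exchange. Compound 1, the weakest here, carries a chlorophenyl on the same ring nitrogen, though with a different core and chain, so a modest loss is expected rather than none. For compound 4 the expected shift in this assay is a 2.9-fold higher number from compound 3 to compound 4 (0.47 log units; beyond the scatter), giving an estimate of 150 nM with a range from 50 nM to 450 nM.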

Compound 4, inhibition constant: 223 nM
For compound 4 the middle estimate is 1.5-fold (0.17 log units) below the measured one; low and high end bracket the measured number.
By their numbers in this assay, from the lowest: compound 3; then compound 2; then compound 4; then compound 1.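

With core and chain held fixed, 4-chlorophenyl in place of 2-(methylsulfanyl)phenyl on the amine nitrogen in the ring gives a 4.4-fold higher number from compound 3 to compound 4 (0.64 log units; beyond the scatter) in this assay. Among the compounds shown here, the aryl group at this position therefore moves the binding number on its own, which the earlier compounds, differing in several places at once, could not show. Nothing shown accounts for the size of this step. Still open, on these data alone, is whether the loss follows from the departing methylsulfanyl group or the entering chlorine. An unsubstituted phenyl or a methoxyphenyl on the same core would help separate the two.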